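Aryl exchange on the shared core: compound 2 to compound 3

A few compounds are considered here, and "the series" means these few. Any claim that something is new, unique, unknown or untested is made for them only; others in the source may bear on it.

In an ADME assay (liver) for metabolic stability, with Liver microsome (Canis lupus familiaris) as the target, read by LC-MS, using microsomes, with a stated time of 30 min, tested at 4 uM (a lower number here means that less of the compound is left, a higher number that more of the compound is left), compound 1 (`COCCn1c(-c2ccccc2Cl)nc2c(N3CCN4C(=O)CCC4C3)nc(C)nc21`) gives 35%, and compound 2 (`Cc1nc(N2CCN(C)CC2)c2nc(-c3cccc(C(F)(F)F)c3)n(C3CCOCC3)c2n1`) gives 44%. Compound 2 therefore stands within the scatter of compound 1, and neither value can be placed ahead of the other. For the measured compounds named here, no step between measured compounds that differ in one place is available, so the size of a single change has not been observed.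

Compound 3 (`Cc1nc(N2CCN(C)CC2)c2nc(-c3ccccc3F)n(C3CCOCC3)c2n1`) has not yet been measured. It keeps the shared core and the oxan-4-yl group of compound 2, with 2-fluorophenyl in place of 3-(trifluoromethyl)phenyl on an aromatic carbon, between two ring nitrogen atoms: 2-fluorophenyl in place of 3-(trifluoromethyl)phenyl on an aromatic carbon. Going by the values given here, with no measured precedent for this exchange, the data point to no direction, and the change in this assay is expected to stay within the scatter. The starting point is compound 2 at 44%. The expected size of the move is a number 2 percentage points higher from compound 2 to compound 3 (within the scatter). For compound 3 the estimated value is 46%, with an expected range of 28% to 64%.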

Compound 3, percent of the compound remaining: 21%
Estimate against measurement, compound 3: 25 percentage points above; the measured number lies below the stated range.
By their numbers in this assay, from the lowest: compound 3; then compounds 1 and 2 (each within the scatter of the next).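

In this assay, the exchange of 3-(trifluoromethyl)phenyl for 2-fluorophenyl on the aromatic carbon between two ring nitrogen atoms gives a number 23 percentage points lower from compound 2 to compound 3 (beyond the scatter) with the shared core and the oxan-4-yl group unchanged. For the compounds shown here, compounds 1 and 2 differ in more than one place and gave no step, whereas this pair shows that a single exchange at this position can move the percent remaining by more than the usual scatter. The direction of the step is now known for this one pair, but nothing measured here accounts for it.

The exchange changes both the substituent on the phenyl ring and its place on that ring, so the step cannot be assigned to either alone. Plain phenyl, 3-fluorophenyl and 2-(trifluoromethyl)phenyl at this position would separate the two, and it remains open whether the step carries over to a compound with another group in place of the oxan-4-yl group, such as a 2-methoxyethyl chain.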